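Moving the methoxy pattern on the urea aryl group

The source may report more compounds than this note shows. Statements on the series, on what has been measured and on what is new or still open speak of the compounds shown alone.

Compound 1 `COc1ccc(NC(=O)Nc2nc(Sc3c[nH]c4ccccc34)cc(N3CCCCC3)n2)cc1` gives 17400 nM in a functional assay on PC-3 cells (Homo sapiens) for inhibition, with a stated time of 72 h; on this read-out lower numbers stand for stronger inhibition and higher numbers for weaker inhibition.
Compound 2 `COc1ccc(NC(=O)Nc2nc(Nc3cc(OC)cc(OC)c3)cc(Sc3c[nH]c4ccccc34)n2)cc1` gives 15100 nM in this assay.
Compound 3 `COc1ccc(NC(=O)Nc2nc(Sc3c[nH]c4ccccc34)cc(N3CCCC3)n2)cc1` gives 21500 nM in this assay.

Compound 2 sits within the scatter of the other two: a 1.2-fold lower number from compound 1 to compound 2 (0.06 log units; within the scatter) and a 1.4-fold higher number from compound 2 to compound 3 (0.15 log units; within the scatter) are both small, as is a 1.2-fold higher number from compound 1 to compound 3 (0.09 log units; within the scatter). Compound 4 `COc1cc(NC(=O)Nc2nc(Nc3cc(OC)cc(OC)c3)cc(Sc3c[nH]c4ccccc34)n2)cc(OC)c1` differs from compound 2 by 3,5-dimethoxyphenyl in place of 4-methoxyphenyl on an amide-type nitrogen. None of the three measured steps touches this part of the molecule; each of them swaps the group on an aromatic carbon of the shared core, and all three stay within the scatter. For the measured compounds named here, the change in compound 4 therefore has no direct precedent here, and with every measured step small, no shift beyond the scatter is expected in this assay. The expected step is a 1.0-fold lower number from compound 2 to compound 4 (0.00 log units; within the scatter). Compound 4 is estimated at 15000 nM, with a range from 5000 nM to 45000 nM.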

Compound 4, half-maximal inhibitory concentration: 11600 nM
Beside the measured number, compound 4's estimate is 1.3-fold (0.11 log units) above it, within the range that was stated.
By their numbers in this assay, from the lowest: compounds 4, 2, 1 and 3 (each within the scatter of the next).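

This is the first step shown on the urea aryl group rather than on an aromatic carbon of the shared core: in this assay, 3,5-dimethoxyphenyl in place of 4-methoxyphenyl on the amide-type nitrogen gives a 1.3-fold lower number from compound 2 to compound 4 (0.11 log units; within the scatter). Going from one methoxy group to two on this aryl group therefore stays within the scatter, as the three steps on the core do. No evidence here bears on what lies behind this result.

As far as these compounds go, whether a plain phenyl or a chain ending in an amine on this nitrogen would move the number beyond the scatter stays open. So does whether this swap gives the same small step with piperidin-1-yl on the core.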